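The source may report more compounds than this note shows. Statements on the series, on what has been measured and on what is new or still open speak of the compounds shown alone.

Measured so far:
compound 1 `O=C(CCSc1nc2cc(Cl)ccc2o1)N1CCS(=O)(=O)C1` — 1.7 mL/min/g
compound 2 `O=C(CCSc1nc2cc(F)ccc2o1)N1CCS(=O)(=O)CC1` — 0.4 mL/min/g

In an ADME assay on microsomes from liver (Homo sapiens) for metabolic stability, read by LC-MS, using NADPH, with a stated time of 45 min, tested at 0.5 uM (on this read-out higher numbers stand for fast clearance and lower numbers for slow clearance), compound 1 gives 1.7 mL/min/g, the highest of the two numbers. Compound 2 gives 0.4 mL/min/g, and the gap between the two lies beyond the usual scatter. Compound 3 `O=C(CCSc1nc2cc(Cl)ccc2o1)N1CCC1` is not yet measured; it differs from compound 1 in one place: azetidin-1-yl in place of 1,1-dioxo-1,3-thiazolidin-3-yl on a carbonyl carbon. Among the measured compounds shown here, no step between measured compounds covers this change, so the expectation rests on compound 1 alone. A moderate rise in this assay is expected, probably beyond the scatter. Compound 3 is estimated at 3 mL/min/g (range 1.2 mL/min/g to 7.5 mL/min/g). The expected step is a 1.8-fold higher number from compound 1 to compound 3 (0.25 log units; within the scatter).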

Compound 3, intrinsic clearance in a liver preparation (reported as CLH), per the amount of preparation that the assay uses: 3.7 mL/min/g
Compound 3: middle estimate off by 1.2-fold (0.09 log units), on the low side; low and high end bracket the measured number.
By their numbers in this assay, from the lowest: compound 2; then compound 1; then compound 3.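

In this assay, azetidin-1-yl in place of 1,1-dioxo-1,3-thiazolidin-3-yl on a carbonyl carbon gives a 2.2-fold higher number from compound 1 to compound 3 (0.34 log units; beyond the scatter). Among the compounds shown here, this is the first readable step: with the rest of compound 1 held constant, the group on this carbonyl carbon alone moves clearance modestly, beyond the usual scatter. No measurement shown here accounts for the rise.

Ring size and ring hetero atoms change together in this step, so their separate contributions remain open. Pyrrolidin-1-yl or morpholin-4-yl on the same carbonyl carbon would help separate them.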